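Compound 3: change at the carbonyl carbon, stability outlook

The source may hold more compounds than are shown below. What is called first, only, known or untested is meant among the compounds shown, and "the series" means these compounds.

Compound 2 `COC[C@]1(C(=O)N2CC[C@](c3ccc(C(F)(C(F)(F)F)C(F)(F)F)cc3)(S(=O)(=O)c3ccc(F)cc3)C2)CC[C@H](C(=O)O)CC1` gives 100% in an ADME assay on microsomes from liver (Homo sapiens) for metabolic stability, with a stated time of 10 min (on this read-out lower numbers stand for a less stable compound and higher numbers for a more stable compound), the highest of the two numbers measured; compound 1 `C[C@]1(C(=O)N2CC[C@](c3ccc(C(F)(C(F)(F)F)C(F)(F)F)cc3)(S(=O)(=O)c3ccc(F)cc3)C2)CC[C@H](C(=O)O)CC1` stands at 80%. Compound 3 `O=C(O)C12CCC(C(=O)N3CC[C@](c4ccc(C(F)(C(F)(F)F)C(F)(F)F)cc4)(S(=O)(=O)c4ccc(F)cc4)C3)(CC1)CC2` differs from compound 2 by a group of 11 heavy atoms (9 carbon, 2 oxygen; 2 six-membered non-aromatic rings of carbon only) in place of a group of 12 heavy atoms (9 carbon, 3 oxygen; one six-membered non-aromatic ring of carbon only), on a carbonyl carbon. Among the measured compounds shown here, the only measured step, a number 20 percentage points higher from compound 1 to compound 2 (beyond the scatter), bears on this change only in that compound 3 carries no methoxy. Compound 3 is therefore expected to sit near compound 1, which gives 80% without the methoxy. The step of a number 15 percentage points lower from compound 2 to compound 3 (beyond the scatter) is expected to be downward. For compound 3 the estimate is 85%, with a range from 65% to 100%.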

Compound 3, percent of the compound remaining: 100%
Compound 3: the middle estimate sits 15 percentage points below what was measured; low and high end bracket the measured number.
By their numbers in this assay, from the lowest: compound 1; then compounds 2 and 3 (each within the scatter of the next).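

In this assay, the methoxy is not required for the higher number at this carbonyl carbon: the group with two six-membered carbon rings carries none, yet gives a number 20 percentage points higher from compound 1 to compound 3 (beyond the scatter). Replacing 4-carboxy-1-(methoxymethyl)cyclohexyl with this group gives no change at the digits printed from compound 2 to compound 3 (within the scatter), so the two groups cannot be told apart in this read-out. Nothing available explains these numbers.

The compounds shown leave open how a tetrazole in place of the carboxylic acid, or an ethoxymethyl chain in place of the methoxymethyl, would read in this assay.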